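From (3,5-dimethylpiperazin-1-yl)sulfonyl to amino on the shared core

This account rests on a few compounds, and the source may have more. Where it says the series, first, only, none or still open, it means among the compounds named here.

In an ADME assay on microsomes from liver (Homo sapiens) for metabolic stability, read by LC-MS, using NADPH, with a stated time of 30 min, tested at 0.1 uM (on this read-out lower numbers stand for a less stable compound and higher numbers for a more stable compound), compound 1 `O=S(=O)(CCO)c1cccc(-c2ccc3nccc(-c4ccncc4)c3n2)c1` gives 95% while compound 2 `O=S(=O)(c1cccc(-c2ccc3nccc(-c4ccncc4)c3n2)c1)N1CC[C@H](O)C1` gives 17% and compound 3 `C[C@@H]1CN(S(=O)(=O)c2cccc(-c3ccc4nccc(-c5ccncc5)c4n3)c2)C[C@H](C)N1` gives 34% as the second highest of the three. Compound 4 `Nc1cccc(-c2ccc3nccc(-c4ccncc4)c3n2)c1` differs from compound 3 by amino in place of (3,5-dimethylpiperazin-1-yl)sulfonyl on an aromatic carbon with amino in place of (3,5-dimethylpiperazin-1-yl)sulfonyl on an aromatic carbon. The measured steps only swap the group on the sulfonyl sulfur. They are large for a number 78 percentage points lower from compound 1 to compound 2 (beyond the scatter) and for a number 61 percentage points lower from compound 1 to compound 3 (beyond the scatter) but modest for a number 17 percentage points higher from compound 2 to compound 3 (beyond the scatter) and all lie beyond the scatter. None removes the sulfonyl, so they guide this change only loosely, and a rise of uncertain size is expected. In this assay the expected step is a number 21 percentage points higher from compound 3 to compound 4 (beyond the scatter) and remains a loose estimate. Compound 4 is therefore estimated at 55% within a range of 20% to 85% for now.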

Compound 4, percent of the compound remaining in the Homo sapiens assay: 78%
The estimate for compound 4 lay 23 percentage points below the measured number, and the stated range covers the measured number.
By their numbers in the Homo sapiens assay, from the lowest: compound 2; then compound 3; then compound 4; then compound 1.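

In the Homo sapiens assay, replacing the whole sulfonyl unit with amino gives a number 44 percentage points higher from compound 3 to compound 4 (beyond the scatter) and a number 61 percentage points higher from compound 2 to compound 4 (beyond the scatter), yet also a number 17 percentage points lower from compound 1 to compound 4 (beyond the scatter), so the sulfonyl alone does not set a low number, as compound 1 keeps it and stays highest. In a physicochemical assay for solubility, read by HPLC, using the shake flask method, measured as kinetic solubility, with a stated time of 20 h, at pH 6.5, tested at 200 uM (on this read-out lower numbers stand for lower solubility and higher numbers for higher solubility), compound 3 gives 180000 nM. In the physicochemical assay, the change from compound 3 to compound 4 comes with a large loss of solubility: the measured solubility of compound 3, 180000 nM, and of compound 4, < 5000 nM, an at least 36-fold lower number (1.55 log units; beyond the scatter) In the physicochemical assay, compound 4 gives < 5000 nM, which is a limit of the assay, not a number: the limit of < 5000 nM in the physicochemical assay, at which 1 of the 2 values shown sits.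

From the compounds shown here alone, it remains open whether a carboxylic acid or an acetamide on this aromatic carbon would combine the high number of compound 4 in the Homo sapiens assay with the high number of compound 3 in the physicochemical assay.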